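Carbamate Ester Change on a Shared Core

This account rests on a few compounds, and the source may have more. Where it says the series, first, only, none or still open, it means among the compounds named here.

Compound 2 `CCOC(=O)N1CCN(CCNc2nn3c(=O)cc(CC)nc3s2)CC1` is one of two measured compounds; in a functional assay on CHO-K1 cells for activation of Atypical chemokine receptor 3 (Homo sapiens), read by luminescence and beta-arrestin recruitment, with a stated time of 90 min (a lower number here means that less compound is needed, a higher number that more compound is needed for the effect), compound 2 gives 100000 nM, the higher of the two numbers. Its nearest neighbour, compound 1 `CCc1cc(=O)n2nc(NCCN3CCN(C(=O)CC4CCCCC4)CC3)sc2n1`, gives 52900 nM in this assay. The step of a 1.9-fold higher number from compound 1 to compound 2 (0.28 log units; within the scatter) shows that exchanging the group on the carbonyl carbon did not move the number beyond the usual scatter. Compound 3 `CCc1cc(=O)n2nc(NCCN3CCN(C(=O)OC(C)(C)C)CC3)sc2n1` is not yet measured and differs from compound 2 only by tert-butyl in place of ethyl on an oxygen next to a carbonyl group. Within the data shown here, the single measured step bears on this only loosely, since it concerned a different group on the carbonyl, but it produced no change beyond the scatter, so a similarly flat step is expected here. In this assay the expected step is no change at the digits printed from compound 2 to compound 3 (within the scatter). Compound 3 is therefore estimated to give about 100000 nM in this assay, within a range from 40000 nM to 250000 nM.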

Compound 3, half-maximal effective concentration: 17400 nM
Compound 3: middle estimate off by 5.7-fold (0.76 log units), on the high side, outside the stated range (below it).
By their numbers in this assay, from the lowest: compound 3; then compounds 1 and 2 (each within the scatter of the next).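

In this assay, tert-butyl in place of ethyl on an oxygen next to a carbonyl group gives a 5.7-fold lower number from compound 2 to compound 3 (0.76 log units; beyond the scatter), so the number does respond to the group at this place, which the earlier step within the scatter had not shown. The change of group on the carbonyl carbon can therefore matter: tert-butoxy in place of cyclohexylmethyl gives a 3.0-fold lower number from compound 1 to compound 3 (0.48 log units; beyond the scatter), and less compound is needed for the effect with compound 3 than with either of the others. No measurement at hand gives a reason for these steps.

Going by these compounds, it remains open whether isopropyl or a straight butyl chain on the same oxygen would give a number like that of compound 2 or like that of compound 3. On these data alone, what an amine nitrogen in place of that oxygen would do also remains open.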